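Reversing the double bond of compound 1

This account rests on a few compounds, and the source may have more. Where it says the series, first, only, none or still open, it means among the compounds named here.

In a functional assay on CCRF-CEM cells (Homo sapiens) for antiproliferative activity, read by MTT assay, with a stated time of 72 h (a higher number here means a weaker inhibitor, a lower number a stronger inhibitor), compound 1 `C=C(Br)C(=O)Nc1ccc2c(c1)/C(=C\c1ccc(C)s1)C(=O)N2` gives 1 nM. Compound 2 `C=C(Br)C(=O)Nc1ccc2c(c1)/C(=C\c1sccc1C)C(=O)N2` gives 0.9 nM, which places the two level with each other. Compound 3 `C=C(Br)C(=O)Nc1ccc2c(c1)/C(=C/c1ccc(C)s1)C(=O)N2` awaits measurement. Its relation to compound 1 is the two compounds have the same atoms and bonds and differ only in configuration as drawn: 1 of 1 stereo elements differ; a double bond is drawn E in compound 1 and Z in compound 3: the double bond is drawn E in compound 1 and Z in compound 3. Going by the values given here, the only measured step is a 1.1-fold lower number from compound 1 to compound 2 (0.05 log units; within the scatter). That step alters the methylthiophenyl group and leaves the configuration unchanged, so it bears on this question only indirectly. Among the compounds with values here, no measured pair tests a reversal of this double bond, so neither the size nor the direction of the change is established. A modest move towards weaker inhibition is the cautious expectation, with a wide margin. The step expected is a 2.5-fold higher number from compound 1 to compound 3 (0.40 log units; beyond the scatter). For compound 3 the estimated value is 2.5 nM, with an expected range of 0.4 nM to 20 nM.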

Compound 3, half-maximal inhibitory concentration: 9 nM
Beside the measured number, compound 3's estimate is 3.6-fold (0.56 log units) below it, and the stated range covers the measured number.
By their numbers in this assay, from the lowest: compounds 2 and 1 (each within the scatter of the next); then compound 3.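

In this assay, reversing the double bond gives a 9.0-fold higher number from compound 1 to compound 3 (0.95 log units; beyond the scatter), whereas exchanging 5-methylthiophen-2-yl for 3-methylthiophen-2-yl gave only a 1.1-fold lower number from compound 1 to compound 2 (0.05 log units; within the scatter). The configuration of this double bond therefore matters here in a way the position of the methyl group on the thiophene did not, and the loss can be assigned to that configuration alone: the fact that compounds 1 and 3 differ only in the configuration as drawn. The reversal weakens the inhibition without abolishing it, as compound 3 still gives 9 nM.

Only this one pair of double-bond isomers is shown, so it remains open whether the 3-methylthiophen-2-yl group of compound 2 would respond to reversal in the same way. Also open, on these data alone, is how either configuration would fare with a phenyl ring or a pyridine ring in place of the methylthiophenyl group.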